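Amide aryl variation on a cyclopropane-dicarboxamide series

This account rests on a few compounds, and the source may have more. Where it says the series, first, only, none or still open, it means among the compounds named here.

Measured so far:
compound 1 `CN(C)C(=O)c1cc2cnc(Nc3ccc(NC(=O)C4(C(=O)Nc5ccc(Cl)c(C(F)(F)F)c5)CC4)cc3)nc2n1C1CCCC1` — 88.1%
compound 2 `Cc1ccc(NC(=O)C2(C(=O)Nc3ccc(Nc4ncc5cc(C(=O)N(C)C)n(C6CCCC6)c5n4)cc3)CC2)cc1` — 90.6%

In a functional assay on A549 cells (Homo sapiens) for inhibition, read by CCK-8 assay, with a stated time of 72 h, tested at 10 uM (on this read-out lower numbers stand for less inhibition of growth and higher numbers for more inhibition of growth at the one concentration tested), compound 2 stands highest of the two numbers, but its nearest neighbour compound 1 sits a number 2.5 percentage points higher from compound 1 to compound 2 (within the scatter), so the two are not separable. Compound 3 `CN(C)C(=O)c1cc2cnc(Nc3ccc(NC(=O)C4(C(=O)Nc5ccc(C(F)(F)F)cc5)CC4)cc3)nc2n1C1CCCC1` is not yet measured. It differs from compound 2 by trifluoromethyl in place of methyl on an aromatic carbon. Among the compounds with values here, the only step that bears on this is the one from compound 1 to compound 2, which also swaps the aryl on the same amide-type nitrogen and which stayed inside the scatter. Compound 3 is therefore expected to show a number 2.6 percentage points lower from compound 2 to compound 3 (within the scatter), no shift beyond scatter. Compound 3 is estimated at 88%, within 78% to 95%.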

Compound 3, percent growth inhibition at one concentration: 87.9%
Beside the measured number, compound 3's estimate is 0.1 percentage points above it; the range from low to high includes it.
By their numbers in this assay, from the lowest: compounds 3, 1 and 2 (each within the scatter of the next).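

In this assay trifluoromethyl in place of methyl on this aromatic carbon gives a number 2.7 percentage points lower from compound 2 to compound 3 (within the scatter) at this position, and 4-(trifluoromethyl)phenyl in place of 4-chloro-3-(trifluoromethyl)phenyl gives a number 0.2 percentage points lower from compound 1 to compound 3 (within the scatter) on the same nitrogen. All three aryl amides therefore remain inseparable at the one concentration tested, so neither change registers on this read-out. Nothing available accounts for this lack of separation.

Still open, as far as these compounds go, is whether an amine or a carboxylic acid on this phenyl ring would move the number beyond the scatter. From the compounds shown here alone, a longer chain in place of the aryl group remains equally open.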